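A few compounds are considered here, and "the series" means these few. Any claim that something is new, unique, unknown or untested is made for them only; others in the source may bear on it.

Measured so far in an ADME assay on MRC5 cells (Homo sapiens) for cytotoxicity, read by fluorescence and resazurin assay, with a stated time of 3 days; on this read-out higher numbers stand for weaker inhibition and lower numbers for stronger inhibition:
- compound 1 `Cc1cn(C2CCN(Cc3cccc(Oc4ccc(Cl)cc4)c3)CC2)c(=O)[nH]c1=O` - 25100 nM
- compound 2 `Cc1cn(C2CCN(Cc3cccc(Oc4ccccc4)n3)CC2)c(=O)[nH]c1=O` - > 64000 nM (a limit of the assay)

Going by the values given here, compound 1 gives the only actual number in this small set, 25100 nM, so it cannot be ranked against a second numerical value. The entry for compound 2, > 64000 nM, is a limit of the assay and not a number.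

The next compound to be read is compound 3 `Cc1cn(C2CCN(Cc3cccc(OC4CCCC4)c3)CC2)c(=O)[nH]c1=O`, which carries cyclopentyl in place of 4-chlorophenyl on an oxygen on an aromatic ring. Among the compounds with values here, the series holds no measured step for this change, so the expectation rests on compound 1 at 25100 nM and remains loose. In this assay a modest move to a higher number, meaning weaker inhibition, is expected, and it may not exceed the usual scatter. The expected change is a 1.4-fold higher number from compound 1 to compound 3 (0.16 log units; within the scatter) and no more than that. A reading reported only as a limit remains possible. For compound 3 the estimated value is 36000 nM, with an expected range from 15000 nM to 64000 nM.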

Compound 3, half-maximal inhibitory concentration: 30300 nM
Compound 3: the middle estimate sits 1.2-fold (0.07 log units) above what was measured; measured number inside the range.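

In this assay the series gains its first readable step, a 1.2-fold higher number from compound 1 to compound 3 (0.08 log units; within the scatter), with cyclopentyl in place of 4-chlorophenyl on an oxygen on an aromatic ring. At this position, then, a five-membered non-aromatic ring of carbon only and a chlorine-bearing six-membered aromatic ring read alike, with two fewer heavy atoms in the entering group and no change in the count of hydrogen-bond donors or acceptors; for this pair, the number does not depend on the group being aromatic or on its chlorine. Compound 2 is a limit of the assay and not a number, and steps to it cannot be read: the limit of > 64000 nM in this assay, at which 1 of the 3 values shown sits.

A single step within the scatter carries no pattern, and the compounds shown do not separate the part played by the chlorine from that of the aromatic ring itself. Also open, going by these compounds, is how the read-out responds to a group of a different kind on the same oxygen, such as an amine, a carboxylic acid or a longer carbon chain, since only carbon rings stand there so far.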